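The source may hold more compounds than are shown below. What is called first, only, known or untested is meant among the compounds shown, and "the series" means these compounds.

Measured so far in a functional assay on A-431 cells (Homo sapiens) for antiproliferative activity, read by MTT assay, with a stated time of 24 h (on this read-out lower numbers stand for stronger inhibition and higher numbers for weaker inhibition), are two compounds:
- compound 1 `Cc1cc(=O)n2nc(SCc3cccc(C(F)(F)F)c3)nc2[nH]1` at 21800 nM 
- compound 2 `Cc1ccc(CSc2nc3[nH]c(C)cc(=O)n3n2)cc1` at 15800 nM 

Among the compounds with values here, compound 1 stands level with compound 2, the only other measured compound, as the two numbers lie within the scatter of each other. Next comes compound 3 `Cc1cc(=O)n2nc(SCc3cccc([N+](=O)[O-])c3)nc2[nH]1` with nitro in place of trifluoromethyl on an aromatic carbon, meta to a large group, counted as nitro in place of trifluoromethyl on an aromatic carbon against compound 1. Within the data shown here, no measured step covers this exchange, so the data give no direct size for it. Among the measured compounds shown here, the only guide is that compound 2 at 15800 nM sits within the scatter of compound 1. On that basis, no step beyond the scatter is expected in this assay in either direction. The expected change is a 1.2-fold lower number from compound 1 to compound 3 (0.08 log units; within the scatter) on this estimate. Compound 3 is estimated at 18000 nM with an expected range from 8000 nM to 40000 nM for now.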

Compound 3, half-maximal inhibitory concentration: > 40000 nM
Compound 3 was reported as a limit; the forecaster's own chance of this, stated with the estimate: 8%; middle value at least 2.2-fold (0.34 log units) away from the limit.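

In this assay, within the data shown here, the exchange gives the first measured step at this position, for nitro in place of trifluoromethyl on an aromatic carbon, meta to a large group: an at least 1.8-fold higher number from compound 1 to compound 3 (0.26 log units; that floor lies within the scatter). For compound 3, the reading of > 40000 nM is a limit of the assay and not a number. The step therefore points towards a higher number, but its floor does not separate the two compounds beyond the scatter, and its full size cannot be read because of this limit: the limit of > 40000 nM in this assay, at which 1 of the 3 values shown sits.

Open, as far as these compounds go, is whether an amine or a carboxylic acid in this same place would stay within the scatter of compound 1 or also reach the limit. Also open, from the compounds shown here alone, is whether the exchange gives a similar step with a longer chain between the sulfur and the aromatic ring.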